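Ring expansion at the chain amine: compound 3 to compound 4

A few compounds are considered here, and "the series" means these few. Any claim that something is new, unique, unknown or untested is made for them only; others in the source may bear on it.

Compound 3, `COc1cc2c(Nc3nc4ccc(C(=O)Nc5c(C)cccc5Cl)cc4s3)ncnc2cc1OCCCN1CCCC1`, carries a pyrrolidin-1-yl group on the propoxy chain. In a functional assay on DLD-1 cells (Homo sapiens) for cytotoxicity, read by WST assay, with a stated time of 72 h (a lower number here means a stronger inhibitor, a higher number a weaker inhibitor), compound 3 gives 60700 nM, the highest of the two numerical values in the set. Compound 1, `COc1cc2c(Nc3nc4ccc(C(=O)Nc5c(C)cccc5Cl)cc4s3)ncnc2cc1OCCCN1CCCCC1C`, differs only in the amine and gives 6700 nM in this assay. Within the data shown here, the only measured step with a number at both ends is a 9.1-fold higher number from compound 1 to compound 3 (0.96 log units; beyond the scatter), so the shape of the amine ring changes the read-out by a clear margin. Compound 2, `COc1cc2c(Nc3nc4ccc(C(=O)Nc5c(C)cccc5C)cc4s3)ncnc2cc1OCCCN1CCCCC1`, with a piperidin-1-yl group and a different amide aryl, gives > 100000 nM in this assay. That value is a limit, not a number (the limit of > 100000 nM in this assay, at which 1 of the 3 values shown sits).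

Compound 4, `COc1cc2c(Nc3nc4ccc(C(=O)Nc5c(C)cccc5Cl)cc4s3)ncnc2cc1OCCCN1CCCCC1`, is the next step: piperidin-1-yl in place of pyrrolidin-1-yl on a saturated chain carbon, three bonds along the chain from an oxygen on an aromatic ring. The change runs in the direction back toward compound 1, since the entering piperidin-1-yl ring lacks only the methyl of the 2-methylpiperidin-1-yl in compound 1. Among the measured compounds shown here, the one step that bears on this, from compound 1 to compound 3, is modest but beyond the scatter; a step of similar size, in the opposite direction, is expected here, though compound 4 need not fully reach the value of compound 1.

The expected step is a 4.0-fold lower number from compound 3 to compound 4 (0.61 log units; beyond the scatter). Compound 4 is estimated at 15000 nM, with a range from 5000 nM to 50000 nM.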

Compound 4, half-maximal inhibitory concentration: 14700 nM
Compound 4: the middle estimate sits 1.0-fold (0.01 log units) above what was measured; the measured number falls inside the stated range.
By their numbers in this assay, from the lowest: compound 1; then compound 4; then compound 3. At a limit, above all of these: compound 2.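

In this assay, among these compounds, the single earlier change of amine now separates into two steps, both beyond the scatter: the change of ring size alone gives a 4.1-fold lower number from compound 3 to compound 4 (0.62 log units; beyond the scatter), and removal of the ring methyl gives a 2.2-fold higher number from compound 1 to compound 4 (0.34 log units; beyond the scatter). At this place on the chain, both the ring size and the methyl of the 2-methylpiperidin-1-yl group therefore register on their own, and the order among the three amines with numerical values runs from 2-methylpiperidin-1-yl through piperidin-1-yl to pyrrolidin-1-yl. The amide aryl also gains a reading, since chloro in place of methyl on an aromatic carbon gives an at least 6.8-fold lower number from compound 2 to compound 4 (0.83 log units; beyond the scatter), but compound 2 stands at a limit and not at a number, so this step is only a bound: the limit of > 100000 nM in this assay, at which 1 of the 4 values shown sits.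

The compounds shown leave open whether the same order extends to a morpholine ring or an open-chain amine such as dimethylamino at the end of the propyl chain, or to a butyl chain carrying the same piperidine ring. From the compounds shown here alone, the true size of the step from methyl to chloro also stays open, as does whether it holds with other amines.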